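The source may hold more compounds than are shown below. What is called first, only, known or untested is meant among the compounds shown, and "the series" means these compounds.

In an ADME assay on PC-12 cells (Rattus norvegicus) for cytotoxicity, read by WST assay, with a stated time of 24 h (on this read-out higher numbers stand for lower toxicity in this test and lower numbers for higher toxicity in this test), compound 1 `O=C(/C=C/c1ccc(O)c(O)c1)CC(=O)/C=C/c1cccc(O)c1O` gives 16000 nM, the lowest number of the three measured compounds. Compound 2 `O=C(/C=C/c1cccc(O)c1O)CC(=O)/C=C/c1cccc(O)c1O` gives 39000 nM and compound 3 `O=C(/C=C/c1cccc(O)c1)CC(=O)/C=C/c1cccc(O)c1O` gives 38000 nM, and a 1.0-fold lower number from compound 2 to compound 3 (0.01 log units; within the scatter). Compound 4 `O=C(/C=C/c1ccc(O)c(O)c1)CC(=O)/C=C/c1cc(O)ccc1O` differs from compound 1 by a single change: 2,5-dihydroxyphenyl in place of 2,3-dihydroxyphenyl on a double-bonded chain carbon bound to a double-bonded chain carbon. The two measured steps that start at compound 1 are both modest, a 2.4-fold higher number from compound 1 to compound 2 (0.39 log units; beyond the scatter) and a 2.4-fold higher number from compound 1 to compound 3 (0.38 log units; beyond the scatter). Both alter the 3,4-dihydroxyphenyl group, which compound 4 keeps, and neither touches the 2,3-dihydroxyphenyl group. Among the measured compounds shown here, no measured compound carries the 2,5-dihydroxyphenyl group, so the direction is uncertain, and only a small rise is expected. The estimated step is a 1.4-fold higher number from compound 1 to compound 4 (0.14 log units; within the scatter). For compound 4 the expected value is 22000 nM, within an estimated range of 9000 nM to 50000 nM.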

Compound 4, half-maximal cytotoxic concentration: 51000 nM
Compound 4: the middle estimate sits 2.3-fold (0.37 log units) below what was measured; measured number outside the range, above it.
By their numbers in this assay, from the lowest: compound 1; then compounds 3, 2 and 4 (each within the scatter of the next).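

Swapping 2,3-dihydroxyphenyl for 2,5-dihydroxyphenyl gives a 3.2-fold higher number from compound 1 to compound 4 (0.50 log units; beyond the scatter) in this assay, which means lower toxicity in this test. Among the compounds shown here, the earlier steps changed only the 3,4-dihydroxyphenyl group, so this is the first sign that the number also responds at this other place, even though the two groups have the same atoms and differ only in how they are joined. Nothing available explains this shift. On these data alone, it remains open whether a phenyl with one hydroxy or a methoxy group here would shift the number, and whether the same swap would have a similar effect in compound 2 or compound 3.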